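Vinyl gives way to 2-aminophenyl

The source may hold more compounds than are shown below. What is called first, only, known or untested is meant among the compounds shown, and "the series" means these compounds.

Compounds measured in a functional assay on MCF7 cells (Homo sapiens) for cytotoxicity, read by MTT assay, with a stated time of 48 h; a lower number here means a stronger inhibitor of growth, a higher number a weaker inhibitor of growth
compound 1 (`Cc1nc2cc(Cl)c(Cl)cc2[nH]1`) gives 28000 nM
compound 2 (`C=CCn1c(C(F)(F)F)nc2cc(Cl)c(Cl)cc21`) gives 87000 nM

Compound 2 holds the higher of these two numbers, and its gap to compound 1 lies beyond the usual scatter. That makes compound 2 the weaker growth inhibitor of the pair. Compound 3 (`Nc1ccccc1Cn1c(C(F)(F)F)nc2cc(Cl)c(Cl)cc21`), not yet measured, carries 2-aminophenyl in place of vinyl on a saturated chain carbon bound to an aromatic nitrogen. Going by the values given here, no measured pair shows this change, so any forecast for it remains loose. Among the compounds with values here, a modest move toward a lower number in this assay is expected because compound 2 at 87000 nM is the higher of only two values. The estimate is thus a 2.5-fold lower number from compound 2 to compound 3 (0.40 log units; beyond the scatter) and may not exceed the scatter. For compound 3 the expected value is 35000 nM (estimated range 10000 nM to 100000 nM).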

Compound 3, concentration for 50% growth inhibition: 55600 nM
Estimate against measurement, compound 3: 1.6-fold (0.20 log units) below; low and high end bracket the measured number.
By their numbers in this assay, from the lowest: compounds 1, 3 and 2 (each within the scatter of the next, the first and the last beyond it).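

In this assay the exchange of vinyl for 2-aminophenyl on a saturated chain carbon bound to an aromatic nitrogen gives a 1.6-fold lower number from compound 2 to compound 3 (0.19 log units; within the scatter), so this position takes an aromatic ring in place of the small vinyl group with no shift beyond the scatter. Going by these compounds alone, compound 1 differs from compound 2 and compound 3 in more than one place, so this is the only single-change comparison that can be read at this position. Nothing shown explains why the change leaves the number within the scatter.

From the compounds shown here alone, it remains open whether plain phenyl would read like 2-aminophenyl, which would separate the ring from its amine. Going by these compounds, it is equally open whether a carboxylic acid or a longer chain at this place would move the number beyond the scatter.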